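Pyridin-4-yl in place of pyridin-3-yl: compound 3 in prospect

This account rests on a few compounds, and the source may have more. Where it says the series, first, only, none or still open, it means among the compounds named here.

In an ADME assay on HEK293 cells (Homo sapiens) for cytotoxicity, read by ATP content, with a stated time of 6 h (on this read-out lower numbers stand for higher toxicity in this test and higher numbers for lower toxicity in this test), compound 1 (`CCCCNc1nc(N)nc2ccn(CC=C(C)C)c12`) gives > 24000 nM, a limit of the assay. Compound 2 (`CCCCNc1nc(N)nc2ccn(Cc3cccnc3)c12`) gives > 24000 nM, likewise a limit. Among the compounds with values here, both stand at the limit of > 24000 nM in this assay, at which 2 of the 2 values shown sit, and the only measured step, a step that the two limits leave unreadable from compound 1 to compound 2, has no size to carry over. Compound 3 (`CCCCNc1nc(N)nc2ccn(Cc3ccncc3)c12`) follows from compound 2 by pyridin-4-yl in place of pyridin-3-yl on a saturated chain carbon bound to an aromatic nitrogen. The expected step, a step that the limit leaves unreadable from compound 2 to compound 3, is none beyond the scatter, and another limit is likely. For compound 3 the estimate is 28000 nM, with an expected range of 14000 nM to 50000 nM.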

Compound 3, half-maximal cytotoxic concentration: > 24000 nM
Compound 3 gave a limit, no number; the forecaster's own chance of this, stated with the estimate: 80%; the middle value lies beyond the limit too.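

No step can be read among compound 1, compound 2 and compound 3 in this assay, since each gives only a limit: the limit of > 24000 nM in this assay, at which 3 of the 3 values shown sit.

The compounds shown leave open whether any change on the shared core gives a readable half-maximal cytotoxic concentration.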